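A Smaller Ring on the Amide Nitrogen of Compound 1

This account rests on a few compounds, and the source may have more. Where it says the series, first, only, none or still open, it means among the compounds named here.

Compound 1 `CC(C)C(NC(=O)NO)C(=O)NC1CCCCC1` was measured in a functional assay on HeLa cells (Homo sapiens) for inhibition (on this read-out lower numbers stand for stronger inhibition and higher numbers for weaker inhibition), and gives > 100000 nM, which is a limit of the assay and not a number. Compound 2 `CCC(C)C(NC(=O)NO)C(=O)NC1CCCCC1` gives in this assay > 100000 nM, again a limit. Compound 3 `CCC(C)C1NC(=O)N(C2CCCC2)C1=O` likewise gives in this assay > 100000 nM, also a limit.

Compound 1 therefore stands only at a limit, and the same holds for every other compound shown: the limit of > 100000 nM in this assay, at which 3 of the 3 values shown sit. Among the measured compounds shown here, the single measured step, a step that the two limits leave unreadable from compound 1 to compound 2, is itself unreadable, since both of its ends are limits.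

The unmeasured compound 4 `CC(C)C(NC(=O)NO)C(=O)NC1CCCC1` differs from compound 1 by cyclopentyl in place of cyclohexyl on an amide-type nitrogen. No measured step bears on this change, and the measurements shown give no number from which a direction could be read. Compound 4 is accordingly expected to sit near the same limit, with an estimate of 150000 nM in a range from 50000 nM to 500000 nM. The step from compound 1 to compound 4 is expected to be a step that the limit leaves unreadable from compound 1 to compound 4, that is, nothing beyond the scatter.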

Compound 4, half-maximal inhibitory concentration: > 100000 nM
Compound 4 was reported as a limit; the forecaster's own chance of this, stated with the estimate: 85%; the middle value does not contradict the limit.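

In this assay compound 1 and compound 4 both stand at a limit and not at a number, so no step between them can be read, and the other compounds shown offer no reading either: the limit of > 100000 nM in this assay, at which 4 of the 4 values shown sit.

The compounds shown leave open which change to the core of compound 1, if any, would give a readable number in this assay at all.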